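The compounds below may be only part of what the source reports. "The series", "measured", "known", "first", "only" and "open" are said of these compounds alone.

Measured compounds:
compound 1 `N=C(NC(=N)NC1CCCC1)Nc1ccc(C(F)(F)F)cc1`, 3300 nM
compound 2 `CC(C)CNC(=N)NC(=N)Nc1ccc(F)cc1F`, 17300 nM
compound 3 `CC(C)CNC(=N)NC(=N)Nc1ccc(C(F)(F)F)cc1`, 2000 nM

All three were run in a functional assay on UMUC3 cells (Homo sapiens) for antiproliferative activity, read by MTT assay, with a stated time of 72 h; on this read-out higher numbers stand for weaker inhibition and lower numbers for stronger inhibition. In this assay compound 3 gives 2000 nM, and compound 1 gives 3300 nM; the difference between them is cyclopentyl in place of isobutyl on an amine nitrogen, and the step of a 1.7-fold higher number from compound 3 to compound 1 (0.22 log units; within the scatter), so the two values cannot be told apart on this read-out. Compound 2 gives 17300 nM in this assay, the highest of the three numbers; its gap to compound 1 and to compound 3 lies beyond the scatter in each case. The difference between the core of compound 2 and the core of compound 3 is not broken down here.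

Compound 4 `N=C(NC(=N)NC1CCCC1)Nc1ccc(F)cc1F` has not been measured. It differs from compound 2 by cyclopentyl in place of isobutyl on an amine nitrogen, the same change already made from compound 3 to compound 1, at a place that reads the same in both pairs. That earlier step sat within the scatter, so little movement is expected from compound 2 to compound 4 either; the estimated step is a 1.4-fold higher number from compound 2 to compound 4 (0.16 log units; within the scatter), leaning slightly toward a higher number because of a 1.7-fold higher number from compound 3 to compound 1 (0.22 log units; within the scatter). On that basis compound 4 is expected to give about 25000 nM in this assay. The expected range for compound 4 runs from 10000 nM to 60000 nM, and since compound 2 already sits high, a limit value rather than a number is a real possibility.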

Compound 4, half-maximal inhibitory concentration: 18400 nM
Compound 4: middle estimate off by 1.4-fold (0.13 log units), on the high side; low and high end bracket the measured number.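

In this assay, cyclopentyl in place of isobutyl on an amine nitrogen gives a 1.1-fold higher number from compound 2 to compound 4 (0.03 log units; within the scatter). Set beside the earlier case, the change reads alike on both cores: the same change on two cores in this assay, a 1.7-fold higher number (0.22 log units; within the scatter) from compound 3 to compound 1 and a 1.1-fold higher number (0.03 log units; within the scatter) from compound 2 to compound 4, 1.6-fold (0.19 log units) apart, within the scatter of two such steps In these two pairs, then, the exchange of isobutylamino for cyclopentylamino leaves the number within the scatter on either core, and the cores cannot be told apart in how they take the change; this does not show that the change is without any effect, since a small shift could lie hidden in the scatter, and two pairs do not establish that the same result would hold on a further core.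

The compounds shown leave open how this amine nitrogen would respond to a group further from these two, such as a longer chain, a phenyl group or a chain ending in a carboxylic acid or an amine. They also leave open whether a different group in place of trifluoromethyl, such as a nitrile or a methoxy group, would take the exchange of isobutyl for cyclopentyl in the same way.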